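A tert-butoxycarbonyl swap on compound 2

A few compounds are considered here, and "the series" means these few. Any claim that something is new, unique, unknown or untested is made for them only; others in the source may bear on it.

In an ADME assay on the whole organism (strain Sprague-Dawley) for pharmacokinetics, with Rattus norvegicus as the target, read by LC-MS (on this read-out lower numbers stand for lower oral bioavailability and higher numbers for higher oral bioavailability), compound 2 (`O=C1N(Cc2ncco2)CCN1c1cccc2c1cnn2-c1ccccc1F`) gives 37% and lies within the scatter of compound 1 (`O=C1N(c2ccncc2)CCN1c1cccc2c1cnn2-c1ccccc1F`) at 28% while compound 3 (`O=C1NCCN1CCOc1nn(-c2ccc(F)cc2F)c2ccc(F)cc12`) at 71% stands beyond the scatter on the high side. Compound 4 (`CC(C)(C)OC(=O)N1CCN(c2cccc3c2cnn3-c2ccccc2F)C1=O`) carries tert-butoxycarbonyl in place of (1,3-oxazol-2-yl)methyl on an amide-type nitrogen in a ring. For the measured compounds named here, only one measured step touches that nitrogen (a number 9 percentage points higher from compound 1 to compound 2 (within the scatter)) and it stays within the scatter. Going by the values given here, compound 3 differs in more than one place and offers no step. No move beyond the scatter is therefore expected, and the estimated change is a number 4 percentage points lower from compound 2 to compound 4 (within the scatter) at most a small one. The expected value for compound 4 is 33% with an estimated range from 14% to 55% in this read-out.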

Compound 4, oral bioavailability: 100%
Estimate against measurement, compound 4: 67 percentage points below, and the stated range ends below it.
By their numbers in this assay, from the lowest: compounds 1 and 2 (each within the scatter of the next); then compound 3; then compound 4.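

In this assay the substituent on the amide-type nitrogen in a ring proves able to move the read-out far: tert-butoxycarbonyl in place of (1,3-oxazol-2-yl)methyl gives a number 63 percentage points higher from compound 2 to compound 4 (beyond the scatter) and tert-butoxycarbonyl in place of pyridin-4-yl gives a number 72 percentage points higher from compound 1 to compound 4 (beyond the scatter) on the same nitrogen. The earlier step of a number 9 percentage points higher from compound 1 to compound 2 (within the scatter) did not show this reach.

On these data alone, whether the gain belongs to the carbonyl or to the tert-butyl part stays open, and an acetyl or methoxycarbonyl group on this nitrogen would separate the two. Nothing available here bears on why the number rises.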